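A few compounds are considered here, and "the series" means these few. Any claim that something is new, unique, unknown or untested is made for them only; others in the source may bear on it.

Compound 1 `COc1ccc(-c2cc(NC(=O)Nc3ccncc3)cc(C(F)(F)F)c2)cn1` and compound 2 `O=C(Nc1ccncc1)Nc1cc(-c2cncnc2)cc(C(F)(F)F)c1` share a core and differ in one place. In a functional assay on SMMC-7721 cells (Homo sapiens) for inhibition, read by MTT assay, with a stated time of 48 h (a higher number here means a weaker inhibitor, a lower number a stronger inhibitor), compound 1 returns only a limit, > 300000 nM, namely (the limit of > 300000 nM in this assay, at which 1 of the 3 values shown sits). Compound 2 gives 3730 nM in this assay, so the change pyrimidin-5-yl in place of 6-methoxypyridin-3-yl on an aromatic carbon brings an at least 80-fold lower number from compound 1 to compound 2 (1.90 log units; beyond the scatter). Compound 3 `COc1ccc(-c2ccc(OC(F)(F)F)c(NC(=O)Nc3nccs3)c2)cn1` gives 44100 nM in this assay; how its core differs from that of compound 1 is not broken down here. Compound 4 `O=C(Nc1nccs1)Nc1cc(-c2cncnc2)ccc1OC(F)(F)F` is not yet measured and carries the change (pyrimidin-5-yl in place of 6-methoxypyridin-3-yl on an aromatic carbon), the same kind of change as before, though here the place is meta to a ((1,3-thiazol-2-yl)carbamoyl)amino group and para to a trifluoromethoxy group rather than meta to a large group and meta to a trifluoromethyl group. Beside the earlier step, a step of a 9.8-fold lower number from compound 3 to compound 4 (0.99 log units; beyond the scatter) is expected for compound 4, resting on compound 3 at 44100 nM and on the measured step of an at least 80-fold lower number from compound 1 to compound 2 (1.90 log units; beyond the scatter). Compound 4 is therefore estimated at 4500 nM in this assay, between 1000 nM and 20000 nM.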

Compound 4, half-maximal inhibitory concentration: 9350 nM
For compound 4 the middle estimate is 2.1-fold (0.32 log units) below the measured one; the measured number falls inside the stated range.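

In this assay, pyrimidin-5-yl in place of 6-methoxypyridin-3-yl again brings a lower number on the second core, with a 4.7-fold lower number from compound 3 to compound 4 (0.67 log units; beyond the scatter), so the direction of the change carries over between these two cores. Its size does not carry over: the same change on two cores in this assay, an at least 80-fold lower number (1.90 log units; beyond the scatter) from compound 1 to compound 2 and a 4.7-fold lower number (0.67 log units; beyond the scatter) from compound 3 to compound 4, at least 17-fold (1.23 log units) apart, beyond the scatter of two such steps. The first step rests on a limit and not a number, and the two cores differ in more than one place, so these compounds do not show which feature of the core sets the size of the step: the limit of > 300000 nM in this assay, at which 1 of the 4 values shown sits.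

As far as these compounds go, it remains open whether a plain phenyl or an unsubstituted pyridin-3-yl in that place would follow the same direction. From the compounds shown here alone, it is also open how the step would run on a core combining the trifluoromethyl group with the 1,3-thiazol-2-yl urea.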